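Trimming the Chain of the Amide Side Group

The source may report more compounds than this note shows. Statements on the series, on what has been measured and on what is new or still open speak of the compounds shown alone.

In a functional assay on HUVEC cells (Homo sapiens) for inhibition (a lower number here means a stronger inhibitor, a higher number a weaker inhibitor), compound 1 `COc1cc(/C=C/C(=O)c2cccc(NC(=O)c3ccc(Cl)cc3Cl)c2)ccc1O` gives 0.4 ug/mL and compound 2 `CCCC(=O)Nc1cccc(C(=O)/C=C/c2ccc(O)c(OC)c2)c1` gives 1.27 ug/mL. Compound 2 therefore has the higher number of the two and is the weaker inhibitor of the pair, by a gap beyond the scatter. Compound 3 `COc1cc(/C=C/C(=O)c2cccc(NC(C)=O)c2)ccc1O` has not yet been measured. Its difference from compound 2 is hydrogen in place of ethyl on a saturated chain carbon bound to a carbonyl carbon. In words, this is hydrogen in place of ethyl on a saturated chain carbon bound to a carbonyl carbon, which turns propyl to methyl. Among the measured compounds shown here, the only measured step bearing on this is a 3.2-fold higher number from compound 1 to compound 2 (0.50 log units; beyond the scatter), a modest change that came with propyl in place of 2,4-dichlorophenyl on a carbonyl carbon. That step removed a ring, whereas this one removes only ethyl. A smaller step is therefore expected in this assay, most likely within the scatter and, if anything, towards a higher number. The expected step is a 1.4-fold higher number from compound 2 to compound 3 (0.15 log units; within the scatter). For compound 3 the estimated value is 1.8 ug/mL, with an expected range from 0.7 ug/mL to 4.5 ug/mL.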

Compound 3, half-maximal inhibitory concentration: 7.06 ug/mL
Compound 3: the middle estimate sits 3.9-fold (0.59 log units) below what was measured; the whole stated range lies below it.
By their numbers in this assay, from the lowest: compound 1; then compound 2; then compound 3.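

In this assay, the ethyl on the saturated chain carbon bound to the carbonyl carbon proves to be far from a silent part of the side group: hydrogen in its place, which turns propyl to methyl, gives a 5.6-fold higher number from compound 2 to compound 3 (0.75 log units; beyond the scatter), a change of the same modest class as the one seen on replacing the ring, a 3.2-fold higher number from compound 1 to compound 2 (0.50 log units; beyond the scatter). The loss of the ring therefore does not account for the whole effect at this position, since the two ends of the series differ by a large change, an 18-fold higher number from compound 1 to compound 3 (1.25 log units; beyond the scatter), and the numbers rise in order from 2,4-dichlorophenyl through propyl to methyl, with none of the three compounds going against that order. No supporting data are available to explain this trend.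

The compounds shown leave open whether a longer chain, such as hexyl, would continue the trend from methyl to propyl or level off. They also leave open how much of the result for compound 1 depends on its two chlorines, which a plain phenyl on the same carbonyl carbon would address.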